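Antinociception of a Pyrimidine Acetamide Series: Ester and Side Chain

A few compounds are considered here, and "the series" means these few. Any claim that something is new, unique, unknown or untested is made for them only; others in the source may bear on it.

Measured compounds:
compound 1 `CC(C)[C@H](NC(=O)CN(c1nc(Cl)nc2[nH]cnc12)C1CC1)C(=O)OCc1ccccc1` with 51.3%
compound 2 `NCCCC[C@H](NC(=O)CN(c1nc(Cl)nc2[nH]cnc12)C1CC1)C(=O)OCc1ccccc1` with 35.3%
compound 3 `NCCCC[C@H](NC(=O)CN(c1nc(Cl)nc2[nH]cnc12)C1CC1)C(=O)O` with 28.8%

All three were tested in a functional assay on the whole organism (Tail, strain ICR) with Mus musculus as the target, in the tail flick test, with a stated time of 90 min, at a dose of 25 umol/kg by the oral route; a higher number here means a stronger effect of the compound at the dose given, a lower number a weaker effect. Compound 1 gives 51.3% there. Compound 2, which carries a different side chain on the same core, gives 35.3%; the change between them is isopropyl in place of 4-aminobutyl on a saturated chain carbon bound to an amide-type nitrogen and a carbonyl carbon and it produced a number 16 percentage points higher from compound 2 to compound 1 (beyond the scatter). Compound 3 differs from compound 2 only in hydrogen in place of benzyl on an oxygen next to a carbonyl group, and this gave a number 6.5 percentage points lower from compound 2 to compound 3 (within the scatter).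

Compound 4 `CC(C)[C@H](NC(=O)CN(c1nc(Cl)nc2[nH]cnc12)C1CC1)C(=O)O` has not been measured. It differs from compound 3 in isopropyl in place of 4-aminobutyl on a saturated chain carbon bound to an amide-type nitrogen and a carbonyl carbon, the same change already seen from compound 2 to compound 1, on the same kind of position, and it is the only other place where that change appears. The cores of compound 3 and compound 4 differ from those of compound 2 and compound 1 by hydrogen in place of benzyl on an oxygen next to a carbonyl group. Because compound 3 gives 28.8% and the earlier change produced a number 16 percentage points higher from compound 2 to compound 1 (beyond the scatter), compound 4 is expected to show a step of similar size, about a number 16.2 percentage points higher from compound 3 to compound 4 (beyond the scatter). Among the measured compounds shown here, the estimate for compound 4 is therefore 45%, with a range from 30% to 60%, resting on only one earlier example of this change.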

Compound 4, a percentage reported as activity, at one dose (the size of the read-out at that dose, not a potency): 30.3%
Beside the measured number, compound 4's estimate is 14.7 percentage points above it, within the range that was stated.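

With a hydrogen in place of the benzyl group on the ester oxygen, isopropyl in place of 4-aminobutyl gives a number 1.5 percentage points higher from compound 3 to compound 4 (within the scatter), so the rise seen with the benzyl group present does not carry over to this core: the same change on two cores in this assay, a number 16 percentage points higher (beyond the scatter) from compound 2 to compound 1 and a number 1.5 percentage points higher (within the scatter) from compound 3 to compound 4, 14.5 percentage points apart, beyond the scatter of two such steps

Read the other way, replacing benzyl with hydrogen gives a number 21 percentage points lower from compound 1 to compound 4 (beyond the scatter), a larger step than the one seen with the 4-aminobutyl side chain: the same change on two cores in this assay, a number 6.5 percentage points lower (within the scatter) from compound 2 to compound 3 and a number 21 percentage points lower (beyond the scatter) from compound 1 to compound 4, 14.5 percentage points apart, beyond the scatter of two such steps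

In these four compounds, then, the effect of each change depends on the other, but this rests on a single set of steps at one dose, and it does not show why the two changes fail to add up or whether the same would hold at other doses.

The compounds shown leave open whether this dependence extends to other side chains, such as a longer chain without an amine or a side chain bearing a carboxylic acid. They also leave open how an ester other than benzyl, such as a methyl ester, would behave with either side chain.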